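From Compound 3 to Compound 4: a Methoxy Substitution

The source may hold more compounds than are shown below. What is called first, only, known or untested is meant among the compounds shown, and "the series" means these compounds.

Of the compounds shown here, three with a shared core have been measured. Compound 1 `Nc1sccc1C(=O)c1ccc(Cl)cc1` gives 50% in an assay on CHO cells for positive allosteric modulation of adenosine receptor A1 (Homo sapiens), read by ERK phosphorylation, tested at 3 uM; a higher number here means a weaker effect of the compound at the concentration tested, a lower number a stronger effect. Compound 2 `COc1ccc(-c2cc(C(=O)c3ccccc3)c(N)s2)cc1` gives 31% in this assay, and compound 3 `Nc1sc(-c2ccccc2)cc1C(=O)c1ccc(Cl)cc1` gives 46% in this assay. On these numbers compound 3 stands second highest of the three; its nearest neighbour is compound 1, within the scatter, and its furthest is compound 2, beyond the scatter. Within the data shown here, the one measured step between compounds that differ in a single place is phenyl in place of hydrogen on an aromatic carbon, and it gave a number 4 percentage points lower from compound 1 to compound 3 (within the scatter).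

Compound 4 `COc1ccc(-c2cc(C(=O)c3ccc(Cl)cc3)c(N)s2)cc1` has not yet been tested in this assay. It differs from compound 3 by methoxy in place of hydrogen on an aromatic carbon. Among the measured compounds shown here, no measured step shows this change on its own: the step from compound 1 to compound 3 concerns another group, and compound 2 and compound 3 differ in two places, so only their two values can be set side by side. Compound 2, which carries the methoxy, gives 31%, a number beyond the scatter below that of compound 3. On that basis compound 4 is expected to give 36%, within a range from 22% to 50%. The expected step is a number 10 percentage points lower from compound 3 to compound 4 (within the scatter), a moderate lowering.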

Compound 4, a percentage reported as activity, at one concentration (the size of the read-out at that concentration, not a potency): 51%
Compound 4: middle estimate off by 15 percentage points, on the low side, and the stated range ends below it.
By their numbers in this assay, from the lowest: compound 2; then compounds 3, 1 and 4 (each within the scatter of the next).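

Read on its own, methoxy in place of hydrogen on an aromatic carbon, para to a large group, gives a number 5 percentage points higher from compound 3 to compound 4 (within the scatter) in this assay and so leaves no difference that can be told from the scatter when the chloro is present. The step that does stand out is the one that adds the chloro, which gives a number 20 percentage points higher from compound 2 to compound 4 (beyond the scatter) in this assay on the methoxy-bearing compounds, a modest change and the only step shown so far that lies beyond the scatter. Nothing available explains either step.

The compounds shown leave open whether a hydroxyl, an amine or a longer chain such as ethoxy at the place para to a large group would also stay within the scatter of compound 3. From the compounds shown here alone, it also remains open whether bromo or a carboxylic acid in place of the chloro would give a step of similar size, and whether the chloro step holds when the methoxy is absent.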